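Cyclopentyl Ether in Place of Propargyl Ether

The compounds below may be only part of what the source reports. "The series", "measured", "known", "first", "only" and "open" are said of these compounds alone.

Of the compounds shown here, three sharing one core have been measured in a physicochemical assay for lipophilicity, using the shake flask method; a lower number here means a more polar compound, a higher number a more lipophilic compound. Compound 1 `Nc1ncnc(Oc2ccc(NC(=O)C3(C(=O)Nc4ccc(F)cc4)CC3)cc2F)c1/C=N/OCC(=O)N1CCOCC1` gives 2.1 and compound 2 `N/N=C/c1c(N)ncnc1Oc1ccc(NC(=O)C2(C(=O)Nc3ccc(F)cc3)CC2)cc1F` gives 2.25; the two lie within the scatter of each other, a number 0.15 log units higher from compound 1 to compound 2 (within the scatter). Compound 3 `C#CCO/N=C/c1c(N)ncnc1Oc1ccc(NC(=O)C2(C(=O)Nc3ccc(F)cc3)CC2)cc1F` gives 3.34, the highest of the three, with a number 1.09 log units higher from compound 2 to compound 3 (beyond the scatter) and a number 1.24 log units higher from compound 1 to compound 3 (beyond the scatter). Compound 4 `Nc1ncnc(Oc2ccc(NC(=O)C3(C(=O)Nc4ccc(F)cc4)CC3)cc2F)c1/C=N/OC1CCCC1` differs from compound 3 by cyclopentyl in place of propargyl on an oxygen. The two large steps onto compound 3 both concern the group on that oxygen, so a further change there is expected to move this assay again, upward, because a number 1.09 log units higher from compound 2 to compound 3 (beyond the scatter) was large. The expected step is a number 0.86 log units higher from compound 3 to compound 4 (beyond the scatter). Compound 4 is therefore estimated at 4.2, within 3.7 to 4.7.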

Compound 4, partition coefficient: 4.27
Compound 4: middle estimate off by 0.07 log units, on the low side; low and high end bracket the measured number.
By their numbers in this assay, from the lowest: compounds 1 and 2 (each within the scatter of the next); then compound 3; then compound 4.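

With a number 0.93 log units higher from compound 3 to compound 4 (beyond the scatter), this position still responds in this assay when one group with no hydrogen-bond donors or acceptors replaces another, here a ring of carbon only for a chain with a triple bond. On this oxygen and the double-bonded nitrogen it sits on, the compounds now span a number 2.02 log units higher from compound 2 to compound 4 (beyond the scatter) and a number 2.17 log units higher from compound 1 to compound 4 (beyond the scatter). Nothing available explains these steps. Still open, as far as these compounds go, is where a pentyl chain on this oxygen would fall, which would set the ring apart from the carbon count, and where a cyclopentyl bearing an amine would fall.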